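The source may report more compounds than this note shows. Statements on the series, on what has been measured and on what is new or still open speak of the compounds shown alone.

Working notes on the series built on the shared core of compound 1 `Cc1nnc(-c2ccc(N3CCC(Oc4ccccc4C(F)(F)F)CC3)nn2)s1`. In an assay on microsomes from liver for inhibition of acyl-CoA desaturase 1 (Rattus norvegicus) (a lower number here means a stronger inhibitor, a higher number a weaker inhibitor), compound 1 gives 2.3 nM. Going by the values given here, compound 2 `FC(F)(F)c1ccccc1OC1CCN(c2ccc(-c3nnco3)nn2)CC1` gives 22 nM in this assay, and the single one-place step measured so far, a 9.6-fold higher number from compound 1 to compound 2 (0.98 log units; beyond the scatter), concerns the group on an aromatic carbon of the core. Compound 3 `CC(=O)c1ccccc1OC1CCN(c2ccc(-n3ccnc3)nn2)CC1` gives 34 nM in this assay, the highest of the three numbers; its gap to compound 2 lies within the scatter, its gap to compound 1 beyond it.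

Compound 4 `c1cn(-c2ccc(N3CCC(Oc4ccc5c(c4)CCC5)CC3)nn2)cn1` is not yet measured. The change from compound 3 is 2,3-dihydro-1H-inden-5-yl in place of 2-acetylphenyl on an oxygen on a saturated carbon. Among the compounds with values here, no measured step touches the group on the oxygen on the saturated carbon, so the one step in hand, on an aromatic carbon, does not bear on this exchange. With no guide among the measured compounds, the expectation is a change no larger than the scatter in either direction, that is an expected 1.1-fold lower number from compound 3 to compound 4 (0.05 log units; within the scatter). Compound 4 is therefore estimated at 30 nM, with a range from 8 nM to 120 nM.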

Compound 4, half-maximal inhibitory concentration: 62 nM
Beside the measured number, compound 4's estimate is 2.1-fold (0.32 log units) below it; the range from low to high includes it.
By their numbers in this assay, from the lowest: compound 1; then compounds 2, 3 and 4 (each within the scatter of the next, the first and the last beyond it).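

Going by these compounds alone, the step of a 1.8-fold higher number from compound 3 to compound 4 (0.26 log units; within the scatter) is the first measured reading on the group on the oxygen on a saturated carbon, and in this assay this exchange stays within the scatter. The 2-acetylphenyl group, with its double bond outside aromatic rings and its hydrogen-bond acceptor, gives way to 2,3-dihydro-1H-inden-5-yl, with a five-membered non-aromatic ring and no hydrogen-bond acceptor, and this single pair shows no difference beyond the scatter. Nothing at hand explains this outcome.

Open, from the compounds shown here alone, is whether the same exchange reads alike with the 5-methyl-1,3,4-thiadiazol-2-yl group of compound 1 on the aromatic carbon, as compound 3 and compound 4 share a different group there. Also open, going by these compounds, is how a group on that oxygen bearing an amine or a carboxylic acid would read.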